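Fluorine on the benzyl arm across two indole cores

This account rests on a few compounds, and the source may have more. Where it says the series, first, only, none or still open, it means among the compounds named here.

Measured so far, in a functional assay on 3T3-L1 cells (Mus musculus) for inhibition, with a stated time of 20 min, tested at 20 uM; on this read-out higher numbers stand for more inhibition at the one concentration tested (going by the name of the read-out) and lower numbers for less inhibition:
Compound 1, `Cc1ccc(S(=O)(=O)N(Cc2cn(Cc3ccc(F)cc3F)nn2)Cc2cn(S(=O)(=O)c3ccc(C)cc3)c3ccccc23)cc1`, gives 12.3%.
Compound 2, `Cc1ccc(S(=O)(=O)N(Cc2cn(Cc3ccccc3)nn2)Cc2cn(S(=O)(=O)c3ccc(C)cc3)c3ccccc23)cc1`, gives 3.4%.
Compound 3, `Cc1ccc(S(=O)(=O)N(Cc2cn(Cc3ccccc3)nn2)Cc2c(C)c3ccccc3n2S(=O)(=O)c2ccc(C)cc2)cc1`, gives -5.9%.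

The unmeasured compound 4 is `Cc1ccc(S(=O)(=O)N(Cc2cn(Cc3ccc(F)cc3F)nn2)Cc2c(C)c3ccccc3n2S(=O)(=O)c2ccc(C)cc2)cc1`. Compound 4 stands to compound 3 as compound 1 stands to compound 2: the change is 2,4-difluorophenyl in place of phenyl on a saturated chain carbon bound to an aromatic nitrogen and, in the measured pair, (2,4-difluorophenyl in place of phenyl on a saturated chain carbon bound to an aromatic nitrogen). The place of the change is the same in both pairs, so the two changes are the same change, made on two different cores. How the core of compound 3 differs from the core of compound 2 is not broken down here.

The measured step, a number 8.9 percentage points higher from compound 2 to compound 1 (within the scatter), is small. Compound 3 has the lowest number of the three, and its gap to compound 2 is within the scatter, while its gap to compound 1 is beyond it. With one measured instance of this change on a related core, the step from compound 3 to compound 4 is expected to be of similar size, a number 8.9 percentage points higher from compound 3 to compound 4 (within the scatter), resting only on the step from compound 2 to compound 1 and on the value of compound 3. Compound 4 is therefore expected to give about 3% in this assay, estimated between -10% and 16%, which keeps it among weak numbers and within the scatter of compound 3.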

Compound 4, a percentage reported as inhibition, at one concentration (the size of the read-out at that concentration, not a potency): -22%
Compound 4: the middle estimate sits 25 percentage points above what was measured; measured number outside the range, below it.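

In this assay, replacing benzyl with 2,4-difluorobenzyl gives a number 16.1 percentage points lower from compound 3 to compound 4 (beyond the scatter), so on this core the change does not repeat the small rise seen on the other core. Within the data shown here, the two measured steps do not agree, which shows that, for these two pairs, the result of this change could not be carried from one core to the other: the same change on two cores in this assay, a number 8.9 percentage points higher (within the scatter) from compound 2 to compound 1 and a number 16.1 percentage points lower (beyond the scatter) from compound 3 to compound 4, 25 percentage points apart, beyond the scatter of two such steps This does not show which feature of the two cores accounts for the difference, and with only one pair on each core it establishes no general rule for the series, nor does it show that the change would lower the number on any other core.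

The compounds shown leave open whether a phenyl carrying a single fluorine, a chlorine or a methoxy group on this arm would follow the step on the core of compound 1 or the step on the core of compound 3. They also leave open whether an amine or a carboxylic acid on the same arm would give steps that differ between the two cores in the same way.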